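The source may hold more compounds than are shown below. What is called first, only, known or untested is meant among the compounds shown, and "the series" means these compounds.

Two compounds share one core and differ in the group attached to an amine nitrogen. Compound 1, `O=C1C=C(NC2CCCCC2)C(=O)c2c1nc1n2[C@H]2OC[C@@H](O)[C@H]2OC1`, carries a cyclohexyl group on that nitrogen, and compound 2, `O=C1C(NC2CCCCC2)=CC(=O)c2c1nc1n2[C@H]2OC[C@@H](O)[C@H]2OC1`, is a close relative carrying the same cyclohexyl group. In a functional assay on MGC-803 cells (Homo sapiens) for inhibition, read by sulforhodamine B assay (on this read-out higher numbers stand for weaker inhibition and lower numbers for stronger inhibition), compound 1 gives > 8000 nM, which is a limit of the assay rather than a number. In this assay compound 2 likewise gives > 8000 nM, again only a limit. Where compound 2 stands is therefore fixed by the limit of > 8000 nM in this assay, at which 2 of the 2 values shown sit: it has no measured number of its own, and no step between the two measured compounds is known. Compound 3, `O=C1C(Nc2cccc(F)c2)=CC(=O)c2c1nc1n2[C@H]2OC[C@@H](O)[C@H]2OC1`, keeps the core of compound 2 and changes one place: 3-fluorophenyl in place of cyclohexyl on an amine nitrogen. For the measured compounds named here, with both measured values sitting at the limit, there is no measured step to lean on, and the direction of this change is open; a move within the usual scatter in either direction, or a modest gain in inhibition, is all that can be expected. For compound 3 the expected value is 6000 nM, with a range from 1500 nM to 20000 nM. The step is expected to read an at least 1.3-fold lower number from compound 2 to compound 3 (0.12 log units; that floor lies within the scatter).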

Compound 3, half-maximal inhibitory concentration: 1470 nM
Estimate against measurement, compound 3: 4.1-fold (0.61 log units) above; measured number outside the range, below it.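

In this assay, putting 3-fluorophenyl in place of cyclohexyl on the amine nitrogen gives an at least 5.4-fold lower number from compound 2 to compound 3 (0.73 log units; beyond the scatter), so the group at this position can decide whether compounds on this core give a measurable number at all. Compound 3 is the first of the compounds shown with a real number rather than a limit, which compounds 1 and 2 could not provide, since neither gave any sign of how far inhibition on this core could be moved. The true size of the step remains unknown and only its floor can be stated, because the starting point of compound 2 is a limit and not a number: the limit of > 8000 nM in this assay, at which 2 of the 3 values shown sit.

The change swaps a non-aromatic ring for an aromatic one and adds a fluorine at the same time, so the compounds shown cannot say which of the two matters; plain phenyl, 3-chlorophenyl or benzyl on the same nitrogen would begin to separate them. Also open, from the compounds shown here alone, is whether 3-fluorophenyl would give a similar gain on the core of compound 1, where the amine stands in a different place.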